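A few compounds are considered here, and "the series" means these few. Any claim that something is new, unique, unknown or untested is made for them only; others in the source may bear on it.

Measured so far:
compound 1 `COc1cc(-c2nn(-c3cccc(NC(=O)c4cccc(C(F)(F)F)c4)c3)cc2-c2ccncc2)ccc1Cl` — > 50000 nM
compound 2 `COc1cc(-c2nn(-c3cccc(NC(=O)Nc4ccc(Cl)c(C(F)(F)F)c4)c3)cc2-c2ccncc2)ccc1Cl` — > 32500 nM

In a functional assay on K562 cells (Homo sapiens) for inhibition, read by sulforhodamine B assay, with a stated time of 48 h (on this read-out higher numbers stand for weaker inhibition of growth and lower numbers for stronger inhibition of growth), compound 2 gives only a limit, > 32500 nM. Compound 1 likewise gives only a limit in this assay, > 50000 nM. Within the data shown here, both values therefore stand at the floor of what this assay resolves (the limit of > 32500 nM in this assay, at which 1 of the 2 values shown sits, (the limit of > 50000 nM in this assay, at which 1 of the 2 values shown sits)), and the single measured step, a step that the two limits leave unreadable from compound 1 to compound 2, cannot be read in size or direction.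

Compound 3 `O=C(Nc1cccc(-n2cc(-c3ccncc3)c(-c3ccc(Cl)c(O)c3)n2)c1)Nc1ccc(Cl)c(C(F)(F)F)c1` is compound 2 with one change: hydrogen in place of methyl on an oxygen on an aromatic ring. Among the measured compounds shown here, no measured step touches this part of the molecule, so nothing here speaks to how the step from compound 2 to compound 3 should run. For the measured compounds named here, the only anchor is that compound 2 itself sits at a limit.

The expectation for compound 3 is thus a step that the limit leaves unreadable from compound 2 to compound 3, meaning no change resolvable beyond the scatter and a fair chance that this assay again returns only a limit. The estimated value for compound 3 in this assay is 40000 nM, within a range of 8000 nM to 150000 nM.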

Compound 3, concentration for total growth inhibition: > 32500 nM
Compound 3 ended at the assay's limit; the forecaster's own chance of this, stated with the estimate: 70%; the middle value is on the limit's open side.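

In this assay compound 3 gives > 32500 nM, which is a limit and not a number. Compound 2 and compound 3 both stop at the same limit, so the step between them, methoxy to hydroxy, cannot be read: the limit of > 32500 nM in this assay, at which 2 of the 3 values shown sit. The compounds shown leave open whether any of them inhibits growth at a concentration this assay can resolve as a number.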